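The source may report more compounds than this note shows. Statements on the series, on what has been measured and on what is new or still open speak of the compounds shown alone.

Measured so far in an ADME assay on cells (Hepatocyte, Homo sapiens) for metabolic stability; a lower number here means slower removal, a higher number faster removal of the compound:
compound 1 `Cc1cc(C)c(-c2ncc[nH]2)cc1NC(=O)c1ccc(OCc2ccccn2)cc1`: 9 uL/min
compound 2 `Cc1cc(C)c(-c2cn(C)cn2)cc1NC(=O)c1ccc(OCc2ccccn2)cc1`: 6 uL/min

Compound 2 gives the lowest of the two numbers; its nearest neighbour is compound 1, and the step of a 1.5-fold lower number from compound 1 to compound 2 (0.18 log units; within the scatter) is within the scatter. Compound 3 `Cc1ncc(-c2cc(NC(=O)c3ccc(OCc4ccccn4)cc3)c(C)cc2C)[nH]1` is the next member. Its change from compound 2: 2-methyl-1H-imidazol-5-yl in place of 1-methyl-1H-imidazol-4-yl on an aromatic carbon. The two have the same atoms, joined differently. Going by the values given here, the only step bearing on this is a 1.5-fold lower number from compound 1 to compound 2 (0.18 log units; within the scatter), which swaps a ring-nitrogen hydrogen for a methyl and stays within the scatter; no step beyond the scatter is expected here, so a 1.3-fold higher number from compound 2 to compound 3 (0.12 log units; within the scatter) is the estimated change. Compound 3 is estimated at 8 uL/min, between 4 uL/min and 16 uL/min.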

Compound 3, intrinsic clearance in a liver preparation (reported as CLH), per the amount of preparation that the assay uses: 12 uL/min
For compound 3 the middle estimate is 1.5-fold (0.18 log units) below the measured one, within the range that was stated.
By their numbers in this assay, from the lowest: compounds 2, 1 and 3 (each within the scatter of the next).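

In this assay the 2-methyl-1H-imidazol-5-yl group gives a 2.0-fold higher number from compound 2 to compound 3 (0.30 log units; within the scatter) and a 1.3-fold higher number from compound 1 to compound 3 (0.12 log units; within the scatter) and so stays level with both earlier groups. This position therefore tolerates a third imidazole arrangement, and going from 0 hydrogen-bond donors to 1 hydrogen-bond donor in the group does not carry the number beyond the scatter. No available evidence accounts for these numbers.

Going by these compounds, whether a group other than an imidazole at this place, such as an amine or a carboxylic acid, would move the number beyond the scatter remains open. So does the response to changes elsewhere on the shared core.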